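Oxime ether quinones: octyl chain in place of phenyl

A few compounds are considered here, and "the series" means these few. Any claim that something is new, unique, unknown or untested is made for them only; others in the source may bear on it.

Measured compounds:
- compound 1, `COc1cc(/C=N/OCc2ccccc2)c(OC)c2c1C(=O)C=CC2=O`: > 10 ug/mL
- compound 2, `CCCCCCCO/N=C(\CCCCCC)c1cc(OC)c2c(c1OC)C(=O)C=CC2=O`: > 10 ug/mL

Both results so far in a functional assay on A549 cells (Homo sapiens) for antiproliferative activity (on this read-out lower numbers stand for an effect already at smaller amounts and higher numbers for an effect only at larger amounts of compound), are limits of the assay rather than numbers. For compound 1 the result is a limit, > 10 ug/mL. For compound 2 the result is likewise a limit, > 10 ug/mL. Going by the values given here, compound 1 thus stands at the limit of > 10 ug/mL in this assay, at which 2 of the 2 values shown sit; where it would sit as a number is not known, and no step between measured compounds can be read off.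

Compound 3, `CCCCCCCCCO/N=C/c1cc(OC)c2c(c1OC)C(=O)C=CC2=O`, differs from compound 1 by octyl in place of phenyl on a saturated chain carbon bound to an oxygen, in words octyl in place of phenyl on a saturated chain carbon bound to an oxygen. Nothing measured speaks for a step beyond the scatter in this assay in either direction; with compound 2, which also carries a long chain on the oxime oxygen, sitting at the same limit, the same outcome is expected. Compound 3 is therefore expected at 15 ug/mL, within 5 ug/mL to 50 ug/mL, most likely again reported as a limit. The expected step is a step that the limit leaves unreadable from compound 1 to compound 3.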

Compound 3, concentration for half-maximal effect: > 10 ug/mL
Compound 3 ended at the assay's limit (the forecaster's own chance of this, stated with the estimate: 70%); the middle value does not contradict the limit.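

In this assay compound 3 gives > 10 ug/mL as a limit, not a number. Going by these compounds alone, no step from compound 1 to compound 3 can be read, as all compounds shown sit at one limit: the limit of > 10 ug/mL in this assay, at which 3 of the 3 values shown sit. The compounds shown leave open whether octyl in place of phenyl on a saturated chain carbon bound to an oxygen makes any difference in this assay and where any of these compounds would sit as a number.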